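Methylating the phenol of compound 3

The source may report more compounds than this note shows. Statements on the series, on what has been measured and on what is new or still open speak of the compounds shown alone.

Going by the values given here, compound 3 `O=C(/C=C/c1ccc2c(c1)B(O)OC2)c1ccccc1O` gives 48800 nM in a functional assay on SK-OV-3 cells (Homo sapiens) for cytotoxicity, read by MTT assay, with a stated time of 48 h (a higher number here means a weaker inhibitor, a lower number a stronger inhibitor), the highest of the three numbers measured so far. Compound 1 `O=C(/C=C/c1ccc2c(c1)B(O)OC2)c1ccccc1` gives 3400 nM and compound 2 `O=C(/C=C/c1ccc2c(c1)B(O)OC2)c1ccccc1F` gives 3700 nM; a 1.1-fold higher number from compound 1 to compound 2 (0.04 log units; within the scatter), so these two sit together, while a 14-fold higher number from compound 1 to compound 3 (1.16 log units; beyond the scatter) and a 13-fold higher number from compound 2 to compound 3 (1.12 log units; beyond the scatter) set compound 3 well apart from both.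

Compound 4 `COc1ccccc1C(=O)/C=C/c1ccc2c(c1)B(O)OC2` differs from compound 3 by methyl in place of hydrogen on an oxygen on an aromatic ring. Among the compounds with values here, no measured step covers a hydroxy turned into a methoxy; the steps that bear on it are the two that introduce the hydroxy, a 14-fold higher number from compound 1 to compound 3 (1.16 log units; beyond the scatter) and a 13-fold higher number from compound 2 to compound 3 (1.12 log units; beyond the scatter), both large in the direction of a higher number. Compound 4 keeps the oxygen of compound 3 but not its hydrogen, so it is expected to stand between compound 3 and the pair of compound 1 and compound 2 rather than to return fully to them. The expected step is a 4.1-fold lower number from compound 3 to compound 4 (0.61 log units; beyond the scatter), a lower number, beyond the scatter. The estimate for compound 4 in this assay is 12000 nM, with a range from 4000 nM to 40000 nM.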

Compound 4, half-maximal inhibitory concentration: 2600 nM
Compound 4: middle estimate off by 4.6-fold (0.66 log units), on the high side; the whole stated range lies above it.
By their numbers in this assay, from the lowest: compounds 4, 1 and 2 (each within the scatter of the next); then compound 3.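

In this assay, methyl in place of hydrogen on the oxygen on the aromatic ring gives a 19-fold lower number from compound 3 to compound 4 (1.27 log units; beyond the scatter) and removes the whole gap that set the hydroxy apart. Compound 4 returns to the level of the other two, with a 1.3-fold lower number from compound 1 to compound 4 (0.12 log units; within the scatter) and a 1.4-fold lower number from compound 2 to compound 4 (0.15 log units; within the scatter) as its steps; since it keeps the oxygen of compound 3, the oxygen alone does not go with the high number, and hydrogen, fluoro and methoxy are not told apart at this position. No measured evidence accounts for the distinct behaviour of the free hydroxy.

Open, as far as these compounds go, is whether a longer chain on this oxygen, such as ethoxy or benzyloxy, stays at this level. Also open, from the compounds shown here alone, is whether an amine on the same aromatic carbon follows the hydroxy or the methoxy.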